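The source may report more compounds than this note shows. Statements on the series, on what has been measured and on what is new or still open speak of the compounds shown alone.

Compound 1 `COc1ccc(CN(C(=O)CCSc2nc3ccccc3o2)c2cc(OC)c(OC)c(OC)c2)cc1`: 12600 nM
Compound 2 `COc1ccc(CN(C(=O)CCCSc2nc3ccccc3o2)c2cc(OC)c(OC)c(OC)c2)cc1`: 11000 nM
Compound 3 `COc1ccc(CN(C(=O)CSc2nncs2)c2cc(OC)c(OC)c(OC)c2)cc1`: not yet measured

In a functional assay on ECa-109 cells for antiproliferative activity against ECa-109 cell line (Homo sapiens), read by MTT assay, with a stated time of 48 h (on this read-out higher numbers stand for weaker inhibition and lower numbers for stronger inhibition), compound 2 gives 11000 nM, a value that cannot be told apart from that of compound 1 at 12600 nM. Both stand in the same range, and only these two numbers are available so far.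

Compound 3 carries (1,3,4-thiadiazol-2-yl)sulfanyl in place of 2-((1,3-benzoxazol-2-yl)sulfanyl)ethyl on a saturated chain carbon bound to a carbonyl carbon.

Going by the values given here, only one measured step bears on this change, a 1.1-fold lower number from compound 1 to compound 2 (0.06 log units; within the scatter), and it stays within the scatter. That step alters the chain alone and keeps (1,3-benzoxazol-2-yl)sulfanyl in both compounds. Among the compounds with values here, no measured step replaces that group, so the data give no firm direction for the larger change made here. A modest move towards weaker inhibition in this assay is the tentative expectation, and the estimated step is a 1.5-fold higher number from compound 2 to compound 3 (0.19 log units; within the scatter), which may prove no larger than the scatter.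

For compound 3 the expected value is 17000 nM, with an estimated range of 5000 nM to 55000 nM.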

Compound 3, half-maximal inhibitory concentration: 9840 nM
Compound 3: the middle estimate sits 1.7-fold (0.24 log units) above what was measured, and the stated range covers the measured number.
By their numbers in this assay, from the lowest: compounds 3, 2 and 1 (each within the scatter of the next).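

In this assay, putting (1,3,4-thiadiazol-2-yl)sulfanyl in place of 2-((1,3-benzoxazol-2-yl)sulfanyl)ethyl on a saturated chain carbon bound to a carbonyl carbon gives a 1.1-fold lower number from compound 2 to compound 3 (0.05 log units; within the scatter), and the same comparison with the other chain gives a 1.3-fold lower number from compound 1 to compound 3 (0.11 log units; within the scatter). The earlier pair changed only the chain and kept the (1,3-benzoxazol-2-yl)sulfanyl group, whereas these steps show that the whole group, including its six-membered aromatic ring of carbon only, can be exchanged for a single five-membered aromatic ring with no change in the reading beyond the scatter. Nothing measured here accounts for this absence of a clear change.

The three compounds therefore mark no direction at this place, and they do not separate the effect of the ring from that of the chain, since compound 3 differs from compound 1 and compound 2 in both. On these data alone, it remains open whether an amine or a carboxylic acid on this saturated chain carbon, or a longer chain carrying the (1,3,4-thiadiazol-2-yl)sulfanyl group, would move the number beyond the scatter in this assay.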